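Two growth inhibitors measured, a third compound awaiting its number

This account rests on a few compounds, and the source may have more. Where it says the series, first, only, none or still open, it means among the compounds named here.

Compound 1, `c1cc(OC2CCCCCC2)ccc1NC1=NCCO1`: 26800 nM
Compound 2, `O=C(CCl)NC(=O)Nc1ccc(C2CCCCC2)cc1`: 1500 nM

Both numbers come from a functional assay on MCF7 cells (Homo sapiens) for inhibition, read by sulforhodamine B assay, with a stated time of 48 h; on this read-out higher numbers stand for weaker inhibition of growth and lower numbers for stronger inhibition of growth. Compound 1 stands highest of the two; the nearest is compound 2, whose number is lower by a gap that lies beyond the usual scatter. Among the measured compounds shown here, no step between compound 1 and compound 2 is recorded, as they differ in more than one place, so only their two values can be set side by side.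

Compound 3, `O=C(CCl)NC(=O)Nc1ccc(OC2CCCCCC2)cc1`, has not yet been measured. It differs from compound 1 in a single place: a group of 7 heavy atoms (3 carbon, 1 nitrogen, 2 oxygen, 1 chlorine; no ring) in place of a group of 5 heavy atoms (3 carbon, 1 nitrogen, 1 oxygen; one five-membered non-aromatic ring with 2 hetero atoms), on a nitrogen on an aromatic ring. For the measured compounds named here, the group that enters is the one compound 2 already carries, and in this assay compound 2 gives 1500 nM. Because compound 2 gives 1500 nM, compound 3 is expected to fall far below compound 1. The step of a 13-fold lower number from compound 1 to compound 3 (1.13 log units; beyond the scatter) is expected to be a large drop, well beyond the scatter. Compound 3 is estimated at 2000 nM, with a range from 500 nM to 8000 nM.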

Compound 3, concentration for 50% growth inhibition: 3600 nM
Compound 3: middle estimate off by 1.8-fold (0.26 log units), on the low side; the measured number falls inside the stated range.
By their numbers in this assay, from the lowest: compound 2; then compound 3; then compound 1.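

In this assay, the step from the five-membered ring with its 2 hetero atoms to ((chloromethyl)carbonyl)carbamoyl, on a nitrogen on an aromatic ring, gives a 7.4-fold lower number from compound 1 to compound 3 (0.87 log units; beyond the scatter). Among the compounds shown here, the earlier compounds allowed only two values to be set side by side, whereas this is a direct reading of the change on the core of compound 1, and the gain lies beyond the scatter. No measurement bearing on the cause of this step is available.

For the compounds shown here, only this one exchange at this place can be read, so it remains open which part of the entering group goes with the lower number. A methyl in place of the chloromethyl, or a plain carbamoyl without the chloromethyl carbonyl, would separate the chlorine and the outer carbonyl from the rest of the group.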